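The compounds below may be only part of what the source reports. "The series", "measured", "known", "first", "only" and "open" are said of these compounds alone.

In a functional assay on HT-1080 cells (Homo sapiens) for cytotoxicity, read by MTT assay, with a stated time of 72 h (on this read-out lower numbers stand for stronger inhibition and higher numbers for weaker inhibition), compound 1 (`COc1cccc(/C=C2\CCC/C(=C\c3cccc(Br)c3)C2=O)c1OC`) gives 12200 nM, compound 2 (`COc1ccccc1/C=C1\CCC/C(=C\c2cccc(OC)c2OC)C1=O`) gives 14100 nM and compound 3 (`COc1cccc(/C=C2\CCC/C(=C\c3cccc(Cl)c3Cl)C2=O)c1OC`) gives 19300 nM. Compound 3 therefore stands level with the other two: a 1.6-fold higher number from compound 1 to compound 3 (0.20 log units; within the scatter) and a 1.4-fold higher number from compound 2 to compound 3 (0.14 log units; within the scatter). Compound 4 (`COc1cccc(/C=C2\CCC/C(=C\c3ccc(O)c(Cl)c3)C2=O)c1OC`) has 3-chloro-4-hydroxyphenyl in place of 2,3-dichlorophenyl on a double-bonded chain carbon bound to a double-bonded ring carbon. The measured exchanges at this place stay small, including a 1.2-fold higher number from compound 1 to compound 2 (0.06 log units; within the scatter). For the measured compounds named here, none of the measured compounds carries the entering group, so the evidence is indirect. No step beyond the scatter is expected in this assay. The expected step is a 1.6-fold lower number from compound 3 to compound 4 (0.21 log units; within the scatter). For compound 4 the estimate is 12000 nM, with an expected range of 4000 nM to 25000 nM.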

Compound 4, half-maximal inhibitory concentration: 14300 nM
Beside the measured number, compound 4's estimate is 1.2-fold (0.08 log units) below it, within the range that was stated.
By their numbers in this assay, from the lowest: compounds 1, 2, 4 and 3 (each within the scatter of the next).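

In this assay the entering 3-chloro-4-hydroxyphenyl, which unlike the earlier groups at this place counts a hydrogen-bond donor, stays level with all three: a 1.3-fold lower number from compound 3 to compound 4 (0.13 log units; within the scatter) and a 1.0-fold higher number from compound 2 to compound 4 (0.01 log units; within the scatter) and a 1.2-fold higher number from compound 1 to compound 4 (0.07 log units; within the scatter) all lie within the scatter. Adding a hydroxyl to the groups shown on a double-bonded chain carbon bound to a double-bonded ring carbon therefore opens no gap in this small set. On these data alone, whether an amine or a carboxylic acid on the phenyl would leave the scatter stays open. No data given here bear on why the steps stay this small.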